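Compound 2 to compound 4: methylcarbamoyl for hydroxy

The source may hold more compounds than are shown below. What is called first, only, known or untested is meant among the compounds shown, and "the series" means these compounds.

Measured in an ADME assay on S9 fraction from liver (Rattus norvegicus) for metabolic stability, with a stated time of 1 h; a higher number here means that more of the compound is left, a lower number that less of the compound is left:
- compound 1 `N#Cc1cnc(NCc2ccccc2C(F)(F)F)cc1N[C@H]1CC[C@@H](O)CC1` gives 31%
- compound 2 `N#Cc1cnc(NCc2cnccc2C(F)(F)F)cc1N[C@H]1CC[C@H](O)CC1` gives 25%
- compound 3 `N#Cc1cnc(NCc2ccccc2C(F)(F)F)cc1N[C@H]1CC[C@@H](C(N)=O)CC1` gives 3%

Compound 2 lies within the scatter of compound 1 and beyond the scatter above compound 3. The next structure is compound 4 `CNC(=O)[C@H]1CC[C@@H](Nc2cc(NCc3cnccc3C(F)(F)F)ncc2C#N)CC1` and the change is 4-(methylcarbamoyl)cyclohexyl in place of 4-hydroxycyclohexyl on a nitrogen on an aromatic ring in the part of the molecule that compound 2 carries as 4-hydroxycyclohexyl. Going by the values given here, the one measured step that bears on this is a number 28 percentage points lower from compound 1 to compound 3 (beyond the scatter) with carbamoyl in place of hydroxy on a saturated ring carbon. That step is modest but beyond the scatter. It does not carry over directly. Among the compounds with values here, compound 2 differs from compound 1 elsewhere in the structure, and no measured pair shows what the methyl on the amide does. Compound 2 also starts with little room, at 25% remaining. A smaller step in the same direction is therefore expected, estimated as a number 16 percentage points lower from compound 2 to compound 4 (beyond the scatter) in this assay on this reading. Compound 4 is estimated at 9% with an expected range from 2% to 24% for the measurement.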

Compound 4, percent of the compound remaining: 53%
Beside the measured number, compound 4's estimate is 44 percentage points below it, and the stated range ends below it.
By their numbers in this assay, from the lowest: compound 3; then compounds 2 and 1 (each within the scatter of the next); then compound 4.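

In this assay there is a number 28 percentage points higher from compound 2 to compound 4 (beyond the scatter), so replacing 4-hydroxycyclohexyl with 4-(methylcarbamoyl)cyclohexyl on this nitrogen on an aromatic ring does not have to lower the number. The only earlier step of this kind, a number 28 percentage points lower from compound 1 to compound 3 (beyond the scatter), runs the other way, so the direction of a change from hydroxy to an amide at this position is not constant across the two pairs shown. Nothing available here accounts for this reversal.

Going by these compounds alone, no pair isolates the methyl on the amide, and compound 3 and compound 4 also differ elsewhere in the structure, so the two differences between them cannot be separated. From the compounds shown here alone, how a carboxylic acid or an ethylcarbamoyl group would read at the same place remains open.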